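This account rests on a few compounds, and the source may have more. Where it says the series, first, only, none or still open, it means among the compounds named here.

Solubility here is read in a physicochemical assay for solubility, in phosphate buffer, measured as kinetic solubility, at pH 7.4 (on this read-out lower numbers stand for lower solubility and higher numbers for higher solubility), a measure of how much of a compound dissolves in water-like buffer. Going by the values given here, compound 1, `Cc1oc(-c2c(F)cccc2F)nc1CN1CCC(C(=O)NCCCN2C[C@H](C)C[C@H](C)C2)CC1`, is one of two compounds measured so far. In this assay compound 1 gives > 72 ug/mL, which is a limit of the assay and not a number. The second compound, compound 2, `Cc1ccccc1-c1nc(CN2CCC(C(=O)NCCN3C[C@H](C)C[C@H](C)C3)CC2)c(C)o1`, shares the same core with a methylphenyl group in place of the difluorophenyl and a shorter chain. In this assay compound 2 gives > 67 ug/mL, again a limit rather than a number. So compound 1 stands only at a limit, and the same is true of the other value: one value sits at the limit of > 67 ug/mL in this assay, at which 1 of the 2 values shown sits, and one at the limit of > 72 ug/mL in this assay, at which 1 of the 2 values shown sits. Among the compounds with values here, no step between measured compounds can be drawn from two limits.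

Compound 3, `COc1cccc(OC)c1-c1nc(CN2CCC(C(=O)NCCCN3C[C@H](C)C[C@H](C)C3)CC2)c(C)o1`, has not yet been measured. It differs from compound 1 in one place: 2,6-dimethoxyphenyl in place of 2,6-difluorophenyl on an aromatic carbon. With both known values sitting at limits, the step of an at least 1.0-fold lower number from compound 1 to compound 3 (0.01 log units; that floor lies within the scatter) is expected to be none beyond the scatter, with compound 3 likely reaching the limit again. Compound 3 is therefore estimated at 70 ug/mL, within a range from 30 ug/mL to 160 ug/mL.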

Compound 3, solubility: > 76 ug/mL
Compound 3: a limit, no number; the forecaster's own chance of this, stated with the estimate: 60%; middle value at least 1.0-fold (0.03 log units) away from the limit.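

In this assay compound 3 gives > 76 ug/mL, a limit of the assay and not a number. Compound 1 also stands only at a limit, so no step can be read between compound 1 and compound 3. The compounds shown leave open whether 2,6-dimethoxyphenyl in place of 2,6-difluorophenyl changes this read-out at all, and by how much.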